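Cyclopropyl for 1-methyl-2-oxopiperidin-4-yl: lipophilicity working notes

This account rests on a few compounds, and the source may have more. Where it says the series, first, only, none or still open, it means among the compounds named here.

Within the data shown here, only two compounds have numbers so far. In a physicochemical assay for lipophilicity, read by HPLC, at pH 7.4 (a higher number here means a more lipophilic compound, a lower number a more polar compound), compound 1 `CCC/N=C1\S/C(=C\c2ccc(O)cc2)C(=O)N1c1ccccc1C` gives 3.5 and compound 2 `CCC/N=C1\S/C(=C\c2ccc(O)c(Cl)c2)C(=O)N1C1CCN(C)C(=O)C1` gives 0.6 as the lower of the two numbers. The gap between them lies beyond the scatter of such measurements. The two structures differ in more than one place, so the gap cannot be assigned to any single change.

The next structure is compound 3 `CCC/N=C1\S/C(=C\c2ccc(O)c(Cl)c2)C(=O)N1C1CC1`, with cyclopropyl in place of 1-methyl-2-oxopiperidin-4-yl on an amide-type nitrogen in a ring. Among the measured compounds shown here, no measured pair shows a change at this place, so the expectation rests on the structural change alone, with the two measured numbers as rough outer marks. A large upward step in this assay is expected, well beyond the scatter, placing compound 3 above compound 2 but probably still short of compound 1. An expected rise of a number 1.80 log units higher from compound 2 to compound 3 (beyond the scatter) is estimated. The estimate for compound 3 is 2.4 (expected range 1.8 to 3.1).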

Compound 3, distribution coefficient: 3.4
Compound 3: middle estimate off by 1.00 log units, on the low side; measured number above the stated range.
By their numbers in this assay, from the lowest: compound 2; then compounds 3 and 1 (each within the scatter of the next).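

Among these compounds, compound 2 and compound 3 form the first pair that differs in one place, and in this assay the pair gives a number 2.80 log units higher from compound 2 to compound 3 (beyond the scatter). The substituent on the amide-type nitrogen in a ring, two ring bonds from the ring sulfur, can therefore carry a large step on its own, with the rest of the structure unchanged. This single step combines several differences, since 1-methyl-2-oxopiperidin-4-yl has 8 heavy atoms, a six-membered ring, a double bond outside aromatic rings and 1 hydrogen-bond acceptor, while cyclopropyl has 3 heavy atoms, a three-membered ring and 0 hydrogen-bond acceptors, and nothing available accounts for the size of the step.

The compounds shown leave open which of these differences matters most, as no structure separates them; a piperidine ring without the carbonyl, or an open-chain group such as a longer alkyl chain, on the same nitrogen would give further one-place comparisons. Also open, on these data alone, is whether a step of this size would recur on a different core, and whether a carboxylic acid or an amine at this position would fall nearer compound 2 or compound 3.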